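Swapping the benzofuran for trifluoromethylphenyl on the thiazole-bearing core

The source may hold more compounds than are shown below. What is called first, only, known or untested is meant among the compounds shown, and "the series" means these compounds.

Compound 1 `Cc1nc(-c2cc3ccccc3o2)sc1COc1ccc2c(c1)OCC2CC(=O)O`: "not determined" (no result reported)
Compound 2 `Cc1nc(-c2ccc(Cl)cc2)sc1COc1ccc2c(c1)OCC2CC(=O)O`: 85.6 nM
Compound 3 `Cc1nc(-c2ccccc2C(F)(F)F)sc1COc1ccc2c(c1)OCC2CC(=O)O`: "not determined" (no result reported)

In a functional assay on CHO cells for agonist activity at Free fatty acid receptor 1 (Homo sapiens), read by FLIPR and calcium flux (on this read-out lower numbers stand for an effect already at smaller amounts and higher numbers for an effect only at larger amounts of compound), compound 1 has no number to stand on; the same holds for compound 3. Only compound 2 gives a figure in this assay, 85.6 nM. Compound 4 `Cc1nc(-c2ccc(C(F)(F)F)cc2)sc1COc1ccc2c(c1)OCC2CC(=O)O` has not yet been measured. It differs from compound 1 by 4-(trifluoromethyl)phenyl in place of 1-benzofuran-2-yl on an aromatic carbon. Since compound 1 itself carries no value, no step size can be drawn from it, and the only anchor in this assay is the figure of compound 2, which shares the core and also carries a plain six-membered carbon ring on the same aromatic carbon. Compound 4 is therefore expected to land near that figure, estimated at 100 nM with a range from 30 nM to 350 nM.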

Compound 4, half-maximal effective concentration: 96.7 nM
Estimate against measurement, compound 4: 1.0-fold (0.01 log units) above; the measured number falls inside the stated range.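

In this assay, trifluoromethyl in place of chloro gives a 1.1-fold higher number from compound 2 to compound 4 (0.05 log units; within the scatter), so on this read-out the two groups cannot be told apart at this position. Compound 4 gives this aromatic carbon a second number, while compound 1 and compound 3 carry no value, so steps involving them cannot be read. Nothing at hand bears on the cause of this sameness. Still open, on these data alone, is how the 1-benzofuran-2-yl group of compound 1 compares, and whether an amine or a carboxylic acid in place of trifluoromethyl would leave the number where it stands.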